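Sulfonyl aryl exchange on the fluoropyridyl pyrrole series

A few compounds are considered here, and "the series" means these few. Any claim that something is new, unique, unknown or untested is made for them only; others in the source may bear on it.

Measured so far:
Compound 1, `CNCc1cc(-c2ccccc2C(F)(F)F)n(S(=O)(=O)c2ccc(C)cc2)c1`: in a functional assay on the whole organism (strain Jcl:SD) for inhibition, with Rattus norvegicus as the target, with stated times of 3 min and 3 h, at a dose of 1 mg/kg by the intravenous route (a higher number here means more inhibition at the dose given (going by the name of the read-out), a lower number less inhibition), compound 1 gives 86%.
Compound 2, `CNCc1cc(-c2cccnc2F)n(S(=O)(=O)c2ccsc2)c1`: in this assay compound 2 gives 98%.

Compound 2 stands highest of the two numbers; compound 1 is the nearest and lies lower by more than the scatter. Compound 3, `CNCc1cc(-c2cccnc2F)n(S(=O)(=O)c2ccccn2)c1`, differs from compound 2 in one place: pyridin-2-yl in place of thiophen-3-yl on a sulfonyl sulfur. Going by the values given here, no pair of measured compounds shows a change of this kind, so no measured step guides it. The step from compound 2 to compound 3 is expected to be small, a number 8 percentage points lower from compound 2 to compound 3 (within the scatter), a slight lowering or none beyond the scatter. Compound 3 is expected to give 90%, in the range 72% to 100%.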

Compound 3, a percentage reported as inhibition, in the whole organism at one dose (the size of the read-out at that dose, not a potency): 81%
For compound 3 the middle estimate is 9 percentage points above the measured one, within the range that was stated.
By their numbers in this assay, from the lowest: compounds 3 and 1 (each within the scatter of the next); then compound 2.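

In this assay, going by these compounds alone, pyridin-2-yl in place of thiophen-3-yl on the sulfonyl sulfur gives a number 17 percentage points lower from compound 2 to compound 3 (beyond the scatter), the first single-place step. The aromatic ring on the sulfonyl sulfur is therefore not a silent position at this dose: this one exchange moves the read-out beyond the scatter. Nothing available accounts for the size of this step.

Still open, as far as these compounds go, is whether the step follows the change from a five-membered to a six-membered ring or the identity of the hetero atom. Plain phenyl and pyridin-3-yl on the sulfonyl sulfur would help separate these two readings.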